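A Smaller Amide Side Chain and Cell Toxicity

The source may report more compounds than this note shows. Statements on the series, on what has been measured and on what is new or still open speak of the compounds shown alone.

Three thiol-bearing amides have been tested in an ADME assay on CEM-SS cells (Homo sapiens) for cytotoxicity, read by XTT assay, with a stated time of 6 days; on this read-out lower numbers stand for higher toxicity in this test and higher numbers for lower toxicity in this test. Compound 1, `NC(=O)CCNC(=O)c1cccc(S)c1`, reaches only the limit of > 100 uM. Compound 2, `CCCC(=O)OCSc1ccccc1C(=O)NC1(C(N)=O)CCCC1`, likewise sits at the limit of > 100 uM. Compound 3, `CCCC(=O)OCSc1ccccc1C(=O)Nc1ccc(C(N)=O)cc1`, gives 39 uM. Compound 2 thus stands at the limit of > 100 uM in this assay, at which 2 of the 3 values shown sit. No pair of these compounds differs in just one place, so no single measured step can be drawn from them.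

Compound 4, `CCCC(=O)OCSc1ccccc1C(=O)NCC(=O)N(C)C`, is compound 2 with one change: (dimethylcarbamoyl)methyl in place of 1-carbamoylcyclopentyl on an amide-type nitrogen. For the measured compounds named here, because compound 2 gives only > 100 uM, no measured step exists that would show how this kind of change moves the read-out. Compound 4 is expected to stay near the same limit, with a step of a number no higher from compound 2 to compound 4 (the limit leaves the size open) that is no larger than the scatter. Compound 4 is therefore estimated at 100 uM, within a range from 50 uM to 200 uM, most likely again reported only as a limit.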

Compound 4, half-maximal toxic concentration: 38.3 uM
For compound 4 the middle estimate is 2.6-fold (0.42 log units) above the measured one, outside the stated range (below it).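

For the compounds shown here, this is the first measured step on an amide-type nitrogen in this set: in this assay, the change gives an at least 2.6-fold lower number from compound 2 to compound 4 (0.41 log units; beyond the scatter). Replacing 1-carbamoylcyclopentyl with (dimethylcarbamoyl)methyl therefore moves the read-out towards higher toxicity in this test, showing that the group on this nitrogen can matter even when the entering group is the smaller of the two. On these data alone, the true size of the step remains unknown, because compound 2 gives a limit rather than a number: the limit of > 100 uM in this assay, at which 2 of the 4 values shown sit.

The five-membered ring and the hydrogen-bond donor leave together in this one change, so the compounds shown cannot say which of them, if either, accounts for the step. As far as these compounds go, a carbamoylmethyl group on the same nitrogen would keep the donor without the ring and separate the two, while the effect of a carboxylic acid there also remains open.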